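Trading the Formyl Group for a Methyl on the Oxazole

The compounds below may be only part of what the source reports. "The series", "measured", "known", "first", "only" and "open" are said of these compounds alone.

Measured so far:
- compound 1, `O=C(CCCCCCc1ccccc1)c1nnn[nH]1`: > 10000 nM; > 10000 nM (2 entries)
- compound 2, `O=C(CCCCCCc1ccccc1)c1nc(C(F)(F)F)co1`: 214 nM
- compound 3, `O=Cc1coc(C(=O)CCCCCCc2ccccc2)n1`: 1510 nM

The read-out throughout is an assay on HEK-293T cells for inhibition of diacylglycerol lipase-alpha (Homo sapiens), read by colorimetric assay; on this read-out higher numbers stand for weaker inhibition and lower numbers for stronger inhibition. Compound 1 gives only a limit in this assay, > 10000 nM; > 10000 nM (2 entries), so no number is known for it. Among the two compounds with a number, compound 3 stands highest, with 1510 nM, and its nearest neighbour is compound 2 at 214 nM. For the measured compounds named here, the one measured step that bears on the change considered here is a 7.1-fold higher number from compound 2 to compound 3 (0.85 log units; beyond the scatter), which shows that the group on this ring carbon shifts the number by a modest but real amount.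

Compound 4, `Cc1coc(C(=O)CCCCCCc2ccccc2)n1`, differs from compound 3 by methyl in place of formyl on an aromatic carbon. Going by the values given here, no measured step covers a methyl at this position, so the expectation rests on the fact that both neighbours of compound 3 in this assay differ by the group at that one carbon. Compound 4 is therefore expected to lie close to compound 3, with a step of a 1.5-fold lower number from compound 3 to compound 4 (0.18 log units; within the scatter). The estimate for compound 4 is 1000 nM, within the range 250 nM to 4000 nM.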

Compound 4, half-maximal inhibitory concentration: > 10000 nM
Compound 4: a limit, no number (the forecaster's own chance of this, stated with the estimate: 10%); middle value at least 10-fold (1.00 log units) away from the limit.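

For compound 4, the result in this assay is a limit and not a number: the limit of > 10000 nM in this assay, at which 1 of the 4 values shown sits.

Even so, the step is clear, with an at least 6.6-fold higher number from compound 3 to compound 4 (0.82 log units; beyond the scatter), so replacing formyl with methyl on this ring carbon costs more than the formyl-for-trifluoromethyl step had suggested. Measured against the best compound in this series, the change is larger still, with an at least 46-fold higher number from compound 2 to compound 4 (1.66 log units; beyond the scatter), and the three groups at this one carbon now fall in a single order: trifluoromethyl gives the lowest number, formyl a higher one, and methyl the highest.

From the compounds shown here alone, the true number for compound 4 remains unknown, so the full size of both steps stays open. Going by these compounds, it is also open whether a nitrile, an amine or a carboxylic acid at this carbon would sit nearer to trifluoromethyl or to methyl.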